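The compounds below may be only part of what the source reports. "The series", "measured", "known", "first", "only" and "open" are said of these compounds alone.

Compound 1, `CS(=O)(=O)Oc1c(C(=O)NCc2ccc(F)cc2)nc(Br)c2cccnc12`, carries a (methylsulfonyl)oxy group on the shared core and was not tested for cytotoxicity: in a functional assay on MCF7 cells (Homo sapiens) for cytotoxicity, read by MTT assay, with a stated time of 72 h (on this read-out higher numbers stand for weaker inhibition and lower numbers for stronger inhibition), compound 1 is recorded as "not determined" (no result reported), so no number fixes where it stands. Two neighbours on the same core give an idea of the range. Compound 2, `CC(C)(C)OC(=O)N1CCN(c2c(C(=O)NCc3ccc(F)cc3)nc(Br)c3cccnc23)CC1`, reaches only a limit of this assay, > 10000 nM, at which (the limit of > 10000 nM in this assay, at which 1 of the 3 values shown sits). Compound 3, `N[C@H]1CC[C@H](Nc2c(C(=O)NCc3ccccn3)nc(Br)c3cccnc23)CC1`, gives 15000 nM in this assay. Both results sit at the weak end of the scale.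

Compound 4, `CNCCCNc1c(C(=O)NCc2ccc(F)cc2)nc(Br)c2cccnc12`, differs from compound 1 by a single exchange on an aromatic carbon of the core: (3-(methylamino)propyl)amino in place of (methylsulfonyl)oxy on an aromatic carbon. Among the measured compounds shown here, since compound 1 has no measured value, no step between the two can be calculated, and the expectation for compound 4 rests on compounds 2 and 3 alone. Given the weak results of compound 2 and compound 3, compound 4 is expected to show similarly weak inhibition in this assay, with a fair chance that only a limit is reported. The estimate for compound 4 in this assay is 12000 nM, with a range from 3000 nM to 50000 nM.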

Compound 4, half-maximal inhibitory concentration: > 10000 nM
Compound 4 was reported as a limit (the forecaster's own chance of this, stated with the estimate: 45%); the middle value lies beyond the limit too.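

In this assay, compound 4 is reported only as a limit, > 10000 nM. Among the compounds shown here, compound 1 offers no number to set against it, so no step between compound 1 and compound 4 can be read. The compounds shown leave open how far a single exchange on the shared core shifts cytotoxicity.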